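Thiophene in Place of Fluorophenyl on the Indoline Core

This account rests on a few compounds, and the source may have more. Where it says the series, first, only, none or still open, it means among the compounds named here.

Compound 1 `COc1ccc(S(=O)(=O)N2CCc3cccc(-c4cc(OC)c(OC)c(OC)c4)c32)cc1` gives 4670 nM in a functional assay on KB-VIN10 cells (Homo sapiens) for inhibition, with a stated time of 72 h; on this read-out lower numbers stand for stronger inhibition and higher numbers for weaker inhibition.
Compound 2 `COc1ccc(S(=O)(=O)N2CCc3cccc(-c4ccc(F)cc4)c32)cc1` gives 94.6 nM in this assay.

Of the two compounds measured, compound 2 stands at the lowest number; its nearest neighbour, compound 1, sits at a higher value, and that gap lies beyond the scatter. Compound 3 `COc1ccc(S(=O)(=O)N2CCc3cccc(-c4cccs4)c32)cc1` has not yet been measured. It differs from compound 2 in one place: thiophen-2-yl in place of 4-fluorophenyl on an aromatic carbon.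

Within the data shown here, no step between two measured compounds of this kind is available, so the size of the change can only be expected, not read off. Compound 3 is expected to stay close to compound 2, with a step of a 1.6-fold higher number from compound 2 to compound 3 (0.20 log units; within the scatter) that may fall within the scatter or slightly weaken inhibition. For compound 3 the estimate is 150 nM, within a range from 40 nM to 600 nM.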

Compound 3, half-maximal inhibitory concentration: 251 nM
Compound 3: middle estimate off by 1.7-fold (0.22 log units), on the low side, within the range that was stated.
By their numbers in this assay, from the lowest: compound 2; then compound 3; then compound 1.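

Among these compounds, the step of a 2.7-fold higher number from compound 2 to compound 3 (0.42 log units; beyond the scatter) in this assay is the first single-place change read at this aromatic carbon, and it shows that the swap of ring is not silent here. Inhibition is modestly weaker with thiophen-2-yl, yet the five-membered aromatic ring with 1 hetero atom still leaves compound 3 far closer to compound 2 than a cautious reader might fear from one exchange of ring. Nothing available explains the size or direction of this step.

The compounds shown leave open whether the loss of the fluorine or the change of ring carries the step, a question that plain phenyl would help to separate. Going by these compounds, how thiophen-3-yl or pyridin-3-yl would fare at this carbon also remains open.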